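The compounds below may be only part of what the source reports. "The series", "measured", "known", "first", "only" and "open" are said of these compounds alone.

Compound 1 `C[C@@H](NC(=O)c1ccc(C#Cc2ccccc2)cn1)C(C)(C)O` gives 60.9% in a functional assay on HEK293 cells for positive allosteric modulation of metabotropic glutamate receptor 5 (Rattus norvegicus), read by fluorescence and calcium flux (a higher number here means a larger maximal response, a lower number a smaller maximal response), the lowest of the three numbers seen, although its nearest neighbour, compound 2 `C[C@@H](NC(=O)c1ccc(C#Cc2ccc(F)cc2F)cn1)C(C)(C)O` with 61.2%, and its furthest, compound 3 `C[C@@H](NC(=O)c1ccc(C#CC2CC2)cn1)C(C)(C)O` with 63.4%, both sit within the scatter of it. Compound 4 `C[C@@H](NC(=O)c1ccc(C#Cc2cccc(F)n2)cn1)C(C)(C)O` differs from compound 1 in one place: 6-fluoropyridin-2-yl in place of phenyl on a triple-bonded carbon. Within the data shown here, the steps that bear on this exchange are a number 0.3 percentage points higher from compound 1 to compound 2 (within the scatter) and a number 2.5 percentage points higher from compound 1 to compound 3 (within the scatter), together with a number 2.2 percentage points higher from compound 2 to compound 3 (within the scatter); none of them left the scatter. Since swapping the group on the triple-bonded carbon has so far moved the maximal response by nothing beyond the scatter, no step beyond the scatter is expected here either. Compound 4 is therefore estimated at 62%, in a range from 52% to 72%. The expected step is accordingly a number 1.1 percentage points higher from compound 1 to compound 4 (within the scatter).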

Compound 4, largest response reached (reported as efficacy), in percent of the reference or control that the assay uses: 63%
Beside the measured number, compound 4's estimate is 1 percentage points below it; the range from low to high includes it.
By their numbers in this assay, from the lowest: compounds 1, 2, 4 and 3 (each within the scatter of the next).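

With 6-fluoropyridin-2-yl, a ring holding a hetero atom and a hydrogen-bond acceptor now sits on the triple-bonded carbon, and in this assay the steps stay within the scatter: a number 2.1 percentage points higher from compound 1 to compound 4 (within the scatter), a number 1.8 percentage points higher from compound 2 to compound 4 (within the scatter) and a number 0.4 percentage points lower from compound 3 to compound 4 (within the scatter). Across the four compounds, this position has thus taken carbon-only rings and a ring with a hetero atom without any step leaving the scatter. Nothing available explains this flatness.

On these data alone, whether an amine, a carboxylic acid or a longer chain on the triple-bonded carbon would leave the maximal response equally level remains open.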